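The source may hold more compounds than are shown below. What is called first, only, known or untested is meant among the compounds shown, and "the series" means these compounds.

Measured in a functional assay on OVCAR-3 cells (Homo sapiens) for antiproliferative activity, read by MTT assay, with a stated time of 24 h; a higher number here means a weaker inhibitor, a lower number a stronger inhibitor:
- compound 1 `Cc1cccc(NNC(=O)c2ccc(NS(=O)(=O)c3cnc(O)nc3O)cc2)c1`: > 20000 nM
- compound 2 `O=C(NNc1ccccc1F)c1ccc(NS(=O)(=O)c2cnc(O)nc2O)cc1`: > 20000 nM
- compound 3 `Cc1ccccc1NNC(=O)c1ccccc1NS(=O)(=O)c1cnc(O)nc1O`: > 20000 nM

Each of these entries is a limit of the assay and not a number. Compound 3 therefore has no exact position, only its limit of > 20000 nM. Going by the values given here, the series so far shows (the limit of > 20000 nM in this assay, at which 3 of the 3 values shown sit).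

Compound 4 `O=C(NNc1ccccc1F)c1ccccc1NS(=O)(=O)c1cnc(O)nc1O` differs from compound 3 in one place, with fluoro in place of methyl on an aromatic carbon, ortho to a large group, turning 2-methylphenyl into 2-fluorophenyl: fluoro in place of methyl on an aromatic carbon.

The nearest measured comparison also brings in 2-fluorophenyl, though it replaces 3-methylphenyl: a step that the two limits leave unreadable from compound 1 to compound 2. Among the compounds with values here, no readable size can be carried over from it, so no step of known size is expected in this assay, in either direction. The expected step is a step that the limit leaves unreadable from compound 3 to compound 4.

Compound 4 will most likely be reported only as a limit again. Compound 4 is estimated at 25000 nM, with an expected range from 12000 nM to 50000 nM.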

Compound 4, half-maximal inhibitory concentration: 9570 nM
Beside the measured number, compound 4's estimate is 2.6-fold (0.42 log units) above it; measured number outside the range, below it.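

In this assay, going by these compounds alone, 2-fluorophenyl in place of 2-methylphenyl gives an at least 2.0-fold lower number from compound 3 to compound 4 (0.32 log units; beyond the scatter), the only step that can be read, as the other is left unreadable by its two limits. The entry for compound 3, > 20000 nM, is a limit and not a number, so this step is a minimum size. Compound 2 carries the same 2-fluorophenyl group on a differently arranged core, yet its entry is also a limit, > 20000 nM, so this group alone does not bring a measurable value here: the limit of > 20000 nM in this assay, at which 3 of the 4 values shown sit.

As far as these compounds go, whether a chloro or methoxy group at this place would give a lower number than compound 4 stays open. So does the effect of an amine or carboxylic acid on this ring.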